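Trading a Fused Lactam for a Smaller Lactam

The source may hold more compounds than are shown below. What is called first, only, known or untested is meant among the compounds shown, and "the series" means these compounds.

Compound 2 `O=C1c2ccccc2CN1c1cnc(NCc2c(F)ccc3c2CCO3)n2cnnc12` was measured in a physicochemical assay for lipophilicity, using the shake flask method, in phosphate buffer, measured as octanol-water partition, with a stated time of 30 min, at pH 7.4 (a lower number here means a more polar compound, a higher number a more lipophilic compound), where compound 2 gives 2.7. That is level with compound 1 `Cn1cc(-c2cnc(NCc3c(F)ccc4c3CCO4)c3cn[nH]c(=O)c23)cn1`, which gives 2.7, and together they are the lowest of the three numbers; compound 3 `CC(=O)N1CCC(c2cnc(NCc3c(F)ccc4c3CCO4)c3cn[nH]c(=O)c23)CC1` gives 2.9. Among the compounds with values here, the only single-place step among the measured compounds, a number 0.20 log units higher from compound 1 to compound 3 (within the scatter), lies within the scatter and swaps rings on a different core, so it bears only loosely on the change now considered. Compound 4 `C[C@H]1CC(=O)N(c2cnc(NCc3c(F)ccc4c3CCO4)n3cnnc23)C1` differs from compound 2 in one place: a group of 7 heavy atoms (5 carbon, 1 nitrogen, 1 oxygen; one five-membered non-aromatic ring with 1 hetero atom) in place of a group of 10 heavy atoms (8 carbon, 1 nitrogen, 1 oxygen; one five-membered non-aromatic ring with 1 hetero atom, one six-membered aromatic ring of carbon only), on an aromatic carbon. Within the data shown here, no measured step removes a six-membered aromatic ring of carbon only, so the expectation rests on the change alone; the step expected is a number 0.90 log units lower from compound 2 to compound 4 (beyond the scatter), a drop beyond the scatter. Compound 4 is therefore estimated at 1.8, with a range from 1.3 to 2.3.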

Compound 4, distribution coefficient: 1.8
Compound 4: middle estimate and measured number agree at the digits printed; the measured number falls inside the stated range.
By their numbers in this assay, from the lowest: compound 4; then compounds 1, 2 and 3 (each within the scatter of the next).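

Within the data shown here, at this position, on an aromatic carbon, 4-methyl-2-oxopyrrolidin-1-yl in place of the larger group gives, in this assay, a number 0.90 log units lower from compound 2 to compound 4 (beyond the scatter) as the first step here that clears the scatter. Among these compounds, the one earlier step, on a different core, stayed within it. Nothing shown gives a reason for this step.

As far as these compounds go, whether the methyl group or the defined stereocentre of the new group matters stays open. So does how an amine or a carboxylic acid on this carbon would read.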